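Trichlorophenyl Variant in an Antiproliferative Series Awaits Testing

The compounds below may be only part of what the source reports. "The series", "measured", "known", "first", "only" and "open" are said of these compounds alone.

The series is examined in an ADME assay on HUVEC cells (Homo sapiens) for antiproliferative activity, read by MTT assay, with a stated time of 48 h; on this read-out lower numbers stand for stronger inhibition and higher numbers for weaker inhibition. Compound 1 `N#CC1=C(N)Oc2c(N)cc3nc4ccccc4nc3c2C12C(=O)N(Cc1cnnn1-c1cccc(C(F)(F)F)c1)c1ccccc12` reaches only the limit of this assay, > 50000 nM. Compound 2 `N#CC1=C(N)Oc2c(N)cc3nc4ccccc4nc3c2C12C(=O)N(Cc1cnnn1-c1c(F)cccc1F)c1ccccc12` likewise gives only a limit, > 50000 nM. The step that the two limits leave unreadable from compound 1 to compound 2 cannot be read because both values sit at the limit of > 50000 nM in this assay, at which 2 of the 2 values shown sit. Compound 3 `N#CC1=C(N)Oc2c(N)cc3nc4ccccc4nc3c2C12C(=O)N(Cc1cnnn1-c1c(Cl)cc(Cl)cc1Cl)c1ccccc12` differs from compound 2 by 2,4,6-trichlorophenyl in place of 2,6-difluorophenyl on an aromatic nitrogen. For the measured compounds named here, the one measured step is unreadable, so no step size can be taken from it; what the two values show is that neither compound 1 nor compound 2 registered a number in this assay. Compound 3 is therefore expected to give a limit again, and the expected step is a step that the limit leaves unreadable from compound 2 to compound 3. The estimate for compound 3 is 70000 nM, with an expected range from 30000 nM to 200000 nM.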

Compound 3, half-maximal inhibitory concentration: 18300 nM
Estimate against measurement, compound 3: 3.8-fold (0.58 log units) above, and the stated range ends above it.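

In this assay, the group on the aromatic nitrogen now proves able to change the read-out: 2,4,6-trichlorophenyl in place of 2,6-difluorophenyl gives an at least 2.7-fold lower number from compound 2 to compound 3 (0.43 log units; beyond the scatter), and 2,4,6-trichlorophenyl in place of 3-(trifluoromethyl)phenyl gives an at least 2.7-fold lower number from compound 1 to compound 3 (0.43 log units; beyond the scatter). Each of these steps starts from a limit, so its size is a minimum, and the step from compound 1 to compound 2 cannot be read. Only compound 3 gives a number, while the other two compounds stay at a limit: the limit of > 50000 nM in this assay, at which 2 of the 3 values shown sit.

The compounds shown leave open whether the step follows the chlorine atoms themselves or their number. They also leave open how a plain phenyl, or a phenyl carrying a methoxy group or an amine, would read at this place.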